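Triazole aryl variation on a shared core: pyridin-2-yl step

This account rests on a few compounds, and the source may have more. Where it says the series, first, only, none or still open, it means among the compounds named here.

In a functional assay on SMMC-7721 cells (Homo sapiens) for cytotoxicity, read by MTT assay, with a stated time of 4 days (on this read-out lower numbers stand for stronger inhibition and higher numbers for weaker inhibition), compound 3 `C=C1C[C@]23C[C@@]1(O)CC[C@H]2c1ccc(OS(=O)(=O)c2ccc(C)cc2)c(C)c1[C@@H]3Cn1cc(-c2ccccc2)nn1` gives only a limit, > 20000 nM. Compound 1 `C=C1C[C@]23C[C@@]1(O)CC[C@H]2c1ccc(OS(=O)(=O)c2ccc(C)cc2)c(C)c1[C@@H]3Cn1cc(-c2ccc(Br)cc2)nn1` likewise sits at a limit in this assay, > 20000 nM. Compound 2 `C=C1C[C@]23C[C@@]1(O)CC[C@H]2c1ccc(OS(=O)(=O)c2ccc(C)cc2)c(C)c1[C@@H]3Cn1cc(-c2ccc(OC)cc2)nn1` also returns a limit there, > 20000 nM. The steps a step that the two limits leave unreadable from compound 1 to compound 2, a step that the two limits leave unreadable from compound 1 to compound 3 and a step that the two limits leave unreadable from compound 2 to compound 3 stay unreadable because of the limit of > 20000 nM in this assay, at which 3 of the 3 values shown sit. Compound 4 `C=C1C[C@]23C[C@@]1(O)CC[C@H]2c1ccc(OS(=O)(=O)c2ccc(C)cc2)c(C)c1[C@@H]3Cn1cc(-c2ccccn2)nn1` differs from compound 3 by pyridin-2-yl in place of phenyl on an aromatic carbon. Going by the values given here, no measured step gives a readable size for this kind of change, and every value so far rests at the limit. Compound 4 is expected to remain at the limit as well, with an estimated value of 30000 nM (range 10000 nM to 100000 nM). The step that the limit leaves unreadable from compound 3 to compound 4 is thus expected to show no readable movement.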

Compound 4, half-maximal inhibitory concentration: > 20000 nM
Compound 4 gave a limit, no number; the forecaster's own chance of this, stated with the estimate: 85%; the middle value does not contradict the limit.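

Going by these compounds alone, no step from compound 4 to compound 1, compound 2 or compound 3 can be read, because all of them rest on one limit: the limit of > 20000 nM in this assay, at which 4 of the 4 values shown sit.

Going by these compounds, whether any aryl group on the triazole gives a readable value in this assay on this shared core stays open.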